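The compounds below may be only part of what the source reports. "The series", "measured", "known", "first", "only" and "open" are said of these compounds alone.

Compound 1, `Cc1ccc(C(=O)Nc2nc(Cl)c3cn(C)nc3n2)cc1`, is the starting point of this small set. In an assay on CHO cells for displacement of a labelled ligand from adenosine receptor A1 (Homo sapiens), read by scintillation counting, with a stated time of 3 h (on this read-out higher numbers stand for weaker inhibition and lower numbers for stronger inhibition), compound 1 gives only a limit of the assay, > 100000 nM. Compound 2, `Cc1ccc(C(=O)Nc2nc(Cl)c3cn(CC(C)(C)C)nc3n2)cc1`, differs from it by tert-butyl in place of hydrogen on a saturated chain carbon bound to an aromatic nitrogen, and in this assay compound 2 gives 11100 nM. That change brought an at least 9.0-fold lower number from compound 1 to compound 2 (0.95 log units; beyond the scatter). Compound 3, `Cn1cc2c(Cl)nc(NC(=O)c3ccccc3)nc2n1`, differs from compound 1 by hydrogen in place of methyl on an aromatic carbon. In this assay compound 3 also gives only a limit of the assay, > 100000 nM. The step between them, a step that the two limits leave unreadable from compound 1 to compound 3, cannot be sized due to the limit of > 100000 nM in this assay, at which 2 of the 3 values shown sit. Compound 4, `CC(C)(C)Cn1cc2c(Cl)nc(NC(=O)c3ccccc3)nc2n1`, has not yet been measured; it differs from compound 3 by tert-butyl in place of hydrogen on a saturated chain carbon bound to an aromatic nitrogen, the same change that separates compound 1 from compound 2, at the same place. As compound 1 and compound 3 both sit at that limit, a comparable gain is expected, so the step is estimated as an at least 5.0-fold lower number from compound 3 to compound 4 (0.69 log units; beyond the scatter). Compound 4 is therefore expected near 20000 nM, within a range from 7000 nM to 100000 nM, though a limit could again be reported.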

Compound 4, inhibition constant: 11000 nM
The estimate for compound 4 lay 1.8-fold (0.26 log units) above the measured number, and the stated range covers the measured number.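

In this assay, tert-butyl in place of hydrogen on a saturated chain carbon bound to an aromatic nitrogen gave an at least 9.0-fold lower number from compound 3 to compound 4 (0.95 log units; beyond the scatter), so the gain seen on the core of compound 1 carried over to the core of compound 3. Once this group was present, hydrogen in place of methyl on an aromatic carbon gave a 1.0-fold lower number from compound 2 to compound 4 (0.00 log units; within the scatter), so compound 2 and compound 4 cannot be told apart in this assay. This shows the same direction on two closely related cores, but it does not show that the gain is equal in size: the same change on two cores in this assay, an at least 9.0-fold lower number (0.95 log units; beyond the scatter) from compound 1 to compound 2 and an at least 9.0-fold lower number (0.95 log units; beyond the scatter) from compound 3 to compound 4; the limit leaves it open whether they differ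

The compounds shown leave open how a longer chain, or a chain carrying an amine or a carboxylic acid, would compare with the neopentyl group. The true numbers of compound 1 and compound 3 also stay open, and the step between them cannot be read: the limit of > 100000 nM in this assay, at which 2 of the 4 values shown sit.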